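A few compounds are considered here, and "the series" means these few. Any claim that something is new, unique, unknown or untested is made for them only; others in the source may bear on it.

Compound 1 `Nc1nc2ccc(OCC(F)(F)F)cc2s1`: 6.5 mg/kg
Compound 2 `Nc1nc2ccc(OC(F)(F)C(F)(F)F)cc2s1`: 2.5 mg/kg
Compound 3 `N#CCn1c(=N)sc2cc(OC(F)(F)F)ccc21`: 3.5 mg/kg

In a functional assay on the whole organism with Rattus norvegicus as the target (on this read-out lower numbers stand for an effect already at smaller amounts and higher numbers for an effect only at larger amounts of compound), compound 3 gives 3.5 mg/kg, the second highest of the three numbers. Its nearest neighbour is compound 2 with 2.5 mg/kg, and the furthest is compound 1 with 6.5 mg/kg; both gaps sit within the usual scatter, so the three compounds cannot be told apart on these numbers.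

Compound 4 `CS(=O)(=O)CCn1c(=N)sc2cc(OC(F)(F)F)ccc21` differs from compound 3 in one place: (methylsulfonyl)methyl in place of cyano on a saturated chain carbon bound to an aromatic nitrogen. Within the data shown here, no pair of measured compounds differs in a single place, so nothing here shows how large such a change moves this assay. The expectation is therefore a step in either direction no larger than the scatter. Compound 4 is estimated at 4 mg/kg, between 1.5 mg/kg and 10 mg/kg, which means an expected 1.1-fold higher number from compound 3 to compound 4 (0.06 log units; within the scatter).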

Compound 4, dose for half-maximal effect: 1.8 mg/kg
Compound 4: middle estimate off by 2.2-fold (0.35 log units), on the high side, within the range that was stated.
By their numbers in this assay, from the lowest: compounds 4, 2, 3 and 1 (each within the scatter of the next, the first and the last beyond it).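

Among these compounds, this is the first comparison in the set that changes only one place: on a saturated chain carbon bound to an aromatic nitrogen, (methylsulfonyl)methyl in place of cyano gives a 1.9-fold lower number from compound 3 to compound 4 (0.29 log units; within the scatter) in this assay. The place therefore accepts a group of five heavy atoms instead of two without a change that stands clear of the scatter. No measurement shown offers an explanation for this step.

On these data alone, whether an amine, a carboxylic acid or a longer chain would be accepted at this place remains open. One step also cannot show how far this assay can move with changes here.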